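The source may hold more compounds than are shown below. What is called first, only, known or untested is meant among the compounds shown, and "the series" means these compounds.

Working notes on the series. In a functional assay on HeLa cells (Homo sapiens) for cytotoxicity, read by MTT assay, with a stated time of 48 h (on this read-out higher numbers stand for weaker inhibition and lower numbers for stronger inhibition), compound 1 (`COc1cc(-c2cc(COCc3cn(Cc4cc(-c5ccccc5)cnc4Cl)nn3)on2)cc(OC)c1OC`) gives 43100 nM and compound 2 (`COc1cc(COCc2cn(Cc3cc(-c4ccccc4)cnc3Cl)nn2)cc(OC)c1OC`) gives 41900 nM so these two sit within the scatter of each other at the high end of the numbers in hand. Compound 3 (`COc1cc(C2=NOC(COCc3cn(Cc4cc(-c5ccc(C)cc5)cnc4Cl)nn3)C2)cc(OC)c1OC`) gives 9700 nM which lies lower than compound 1 by more than the scatter.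

Compound 4 (`COc1cc(-c2cc(COCc3cn(Cc4cc(-c5ccc(F)cc5)cnc4Cl)nn3)on2)cc(OC)c1OC`) differs from compound 1 by one change (fluoro in place of hydrogen on an aromatic carbon): fluoro in place of hydrogen on an aromatic carbon, para to a large group, taking phenyl to 4-fluorophenyl.

For the measured compounds named here, no two measured compounds differ in one place only, so no measured step speaks directly to this change. Compound 3 (9700 nM) also carries a group on that phenyl, but it differs from compound 1 elsewhere too and supports only a slight lean toward a lower number. In this assay no step beyond the scatter is expected. The estimated step is small (a 1.3-fold lower number from compound 1 to compound 4 (0.13 log units; within the scatter)). The expected value for compound 4 is 32000 nM within an estimated range of 14000 nM to 70000 nM for this read-out.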

Compound 4, half-maximal inhibitory concentration: 37300 nM
For compound 4 the middle estimate is 1.2-fold (0.07 log units) below the measured one, within the range that was stated.
By their numbers in this assay, from the lowest: compound 3; then compounds 4, 2 and 1 (each within the scatter of the next).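

In this assay, for the compounds shown here, fluoro in place of hydrogen on an aromatic carbon, para to a large group, gives the first single-change step: a 1.2-fold lower number from compound 1 to compound 4 (0.06 log units; within the scatter) and so lies within the scatter. At this position, then, taking phenyl to 4-fluorophenyl shows no measurable effect on the read-out, and compound 4 stays among the high numbers in hand. No measurement in hand accounts for the size of this step.

On these data alone, whether an amine, a carboxylic acid or a longer chain at this position would give a step beyond the scatter remains open. Compound 3 carries more than one difference from compound 1, so the part played by each of those differences also remains unresolved.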